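A few compounds are considered here, and "the series" means these few. Any claim that something is new, unique, unknown or untested is made for them only; others in the source may bear on it.

Measured in a functional assay on KB cells (Homo sapiens) for inhibition; a lower number here means that less compound is needed, a higher number that more compound is needed for the effect:
- compound 1 `Cc1cn([C@H]2C[C@H](n3cc(C4CN5CCC4C[C@H]5[C@H](O)c4ccnc5ccccc45)nn3)[C@@H](CO)O2)c(=O)[nH]c1=O`: 11.6 ug/mL
- compound 2 `C=CC1CN2CCC1C[C@@H]2[C@@H](OCc1cn([C@H]2C[C@H](n3cc(C)c(=O)[nH]c3=O)O[C@@H]2CO)nn1)c1ccnc2ccc(OC)cc12`: 3.9 ug/mL

Compound 2, at 3.9 ug/mL, has the lower of the two numbers, and its gap to compound 1 lies beyond the usual scatter of repeated measurements. Compound 3 `C=CC1CN2CCC1C[C@@H]2[C@@H](OCc1cn([C@H]2C[C@H](n3cc(C)c(=O)[nH]c3=O)O[C@@H]2CO)nn1)c1ccnc2ccccc12` departs from compound 2 in one place: hydrogen in place of methoxy on an aromatic carbon. In words, hydrogen replaces methoxy on an aromatic carbon, turning 6-methoxyquinolin-4-yl into quinolin-4-yl. Among the compounds with values here, no measured pair shows this change alone, because compound 1 and compound 2 differ in more than one place, so the expectation is uncertain. The number in this assay is expected to stay close to that of compound 2, perhaps rising slightly. The estimated 1.4-fold higher number from compound 2 to compound 3 (0.15 log units; within the scatter) is small and probably within the scatter. For compound 3 the estimated value is 5.5 ug/mL, with an expected range of 2.5 ug/mL to 13 ug/mL.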

Compound 3, concentration for half-maximal effect: > 100 ug/mL
Compound 3: no number, only a limit (the forecaster's own chance of this, stated with the estimate: 8%); at least 18-fold (1.25 log units) between middle value and limit.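

In this assay, within the data shown here, putting hydrogen in place of methoxy on this aromatic carbon, which turns 6-methoxyquinolin-4-yl into quinolin-4-yl, comes with an at least 25-fold higher number from compound 2 to compound 3 (1.40 log units; beyond the scatter), the first single change whose effect can be read. This pair shows that the position is far from indifferent: a group of only two heavy atoms separates a measurable number from no number at all. Compound 3 carries no number, only a limit of the assay: the limit of > 100 ug/mL in this assay, at which 1 of the 3 values shown sits.

As far as these compounds go, the true value of compound 3 remains unknown, so the full size of this step stays open. Also open, from the compounds shown here alone, is whether methoxy itself matters or whether another group on this carbon, such as hydroxyl, ethoxy or a chlorine atom, would give a similar number.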